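The source may hold more compounds than are shown below. What is called first, only, known or untested is meant among the compounds shown, and "the series" means these compounds.

Compound 2, `Cc1nc2c([nH]1)C(=O)/C(=N/c1ccccc1)C(Cl)=C2O`, gives the highest of the two numbers in hand in a functional assay on HUVEC cells (Homo sapiens) for antiproliferative activity (on this read-out lower numbers stand for stronger inhibition and higher numbers for weaker inhibition), at 1200 nM, with compound 1, `Cc1nc2c([nH]1)C(=O)/C(=N/c1ccc(C(F)(F)F)cc1)C(Cl)=C2O`, nearest at 600 nM. Going by the values given here, the only step measured so far, a 2.0-fold higher number from compound 1 to compound 2 (0.30 log units; within the scatter), lies within the scatter, so the two compounds cannot be ordered on these data. Compound 3, `Cc1nc2c([nH]1)C(=O)/C(=N/c1cccc(Br)c1)C(Cl)=C2O`, differs from compound 2 by bromo in place of hydrogen on an aromatic carbon. Among the compounds with values here, no measured step places a bromo on this ring; the one step that does bear on the ring, the loss of a trifluoromethyl on an aromatic carbon, moved the number by a 2.0-fold higher number from compound 1 to compound 2 (0.30 log units; within the scatter), which is within the scatter. On that basis a step of a 1.5-fold lower number from compound 2 to compound 3 (0.18 log units; within the scatter) is expected for compound 3, with no direction claimed beyond the scatter. Compound 3 is therefore estimated at 800 nM in this assay, within a range from 300 nM to 2500 nM.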

Compound 3, half-maximal inhibitory concentration: 800 nM
Beside the measured number, compound 3's estimate shows no gap at the digits printed; low and high end bracket the measured number.
By their numbers in this assay, from the lowest: compounds 1, 3 and 2 (each within the scatter of the next).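

In this assay, the change from phenyl to 3-bromophenyl gives a 1.5-fold lower number from compound 2 to compound 3 (0.18 log units; within the scatter) and so stays within the scatter, which shows that a single bromine atom on this aromatic carbon, meta to a large group, leaves the number unresolved from that of the unsubstituted phenyl. Going by these compounds alone, the earlier step, a 2.0-fold higher number from compound 1 to compound 2 (0.30 log units; within the scatter), concerned trifluoromethyl and not this place on the ring, so this is the first reading for a group at this position, and it too shows no separation. Nothing at hand bears on why the number stands where it does.

From the compounds shown here alone, whether an amine, a carboxylic acid or a methoxy group at this same place would read differently remains open. Also open is whether any group on this ring can move the number in this assay beyond the scatter, since both steps shown stay within it.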